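The source may report more compounds than this note shows. Statements on the series, on what has been measured and on what is new or still open speak of the compounds shown alone.

Compound 1 `CS(=O)(=O)c1ccc(-c2cnc3[nH]cc(-c4nnc(-c5cccnc5)o4)c(=O)c3c2)cc1` — 14.7%
Compound 2 `N#Cc1ccc(-c2cnc3[nH]cc(-c4nnc(-c5ccc(F)cc5)o4)c(=O)c3c2)cc1` — 18.9%
Compound 3 `O=c1c(-c2nnc(-c3ccc(Cl)cc3)o2)c[nH]c2ncc(-c3ccccc3)cc12` — 21.6%

In a functional assay on HCT-116 cells (Homo sapiens) for inhibition, read by MTT assay, with a stated time of 24 h, tested at 10 uM (on this read-out lower numbers stand for less inhibition of growth and higher numbers for more inhibition of growth at the one concentration tested), compound 1 gives 14.7%, the lowest of the three numbers shown. The two other compounds stand close to it: compound 2 gives 18.9% and compound 3 gives 21.6%, and both gaps to compound 1 fall within the usual scatter of this assay, so the three numbers cannot be told apart. All three compounds share a common core and differ in the two aryl groups attached to it, and none of the pairs differs in only one place, so no single structural step can be read from the measured set.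

Compound 4 `Cc1cccc(-c2nnc(-c3c[nH]c4ncc(-c5ccc(S(C)(=O)=O)cc5)cc4c3=O)o2)c1` is unmeasured. It keeps the core and the methylsulfonylphenyl group of compound 1 and differs in one place: 3-methylphenyl in place of pyridin-3-yl on an aromatic carbon. Going by the values given here, since no comparable step among the measured compounds exists, and since the three measured numbers themselves lie within the scatter of one another, the step from compound 1 to compound 4 is expected to be small and in no clear direction, a number 3.3 percentage points higher from compound 1 to compound 4 (within the scatter), not beyond the scatter. Compound 4 is estimated to give 18% in this assay, with a range from 5% to 32%.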

Compound 4, percent growth inhibition at one concentration: 25.2%
The estimate for compound 4 lay 7.2 percentage points below the measured number; the range from low to high includes it.
By their numbers in this assay, from the lowest: compounds 1, 2, 3 and 4 (each within the scatter of the next, the first and the last beyond it).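

In this assay, going by these compounds alone, putting 3-methylphenyl in place of pyridin-3-yl on the aromatic carbon of the five-membered ring gives a number 10.5 percentage points higher from compound 1 to compound 4 (beyond the scatter), the only step in the set that differs in one place. With the shared core and the methylsulfonylphenyl group held constant, this shows that the group at this position can move the number beyond the scatter, here when a ring with one hetero atom gives way to a ring of carbon only. No measurement shown accounts for this step.

The compounds shown leave open whether the step follows the methyl group or the loss of the ring nitrogen, which a plain phenyl at this carbon would separate. They also leave open how an amine or a carboxylic acid on this ring would read, and whether the exchange gives a similar step with a nitrile-bearing phenyl in place of the methylsulfonylphenyl group.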